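The source may hold more compounds than are shown below. What is called first, only, known or untested is meant among the compounds shown, and "the series" means these compounds.

Measured compounds in an ADME assay on L6 cells (Rattus norvegicus) for cytotoxicity, read by resazurin assay, with a stated time of 70 h; a lower number here means a stronger inhibitor, a higher number a weaker inhibitor:
compound 1, `COc1cc(NC(C)CCCNC(=O)/C=C/c2cccc(C(F)(F)F)c2)c2ncccc2c1`: 16200 nM
compound 2, `COc1cc(NC(C)CCCNC(=O)NNC(=O)/C(C)=C/c2ccccc2)c2ncccc2c1`: 36500 nM

In this assay compound 1 gives 16200 nM, while compound 2 gives 36500 nM. Compound 2 therefore stands at the highest of the two numbers; its nearest neighbour is compound 1, whose number is lower by a gap that lies beyond the usual scatter. Among the compounds with values here, no two measured compounds differ in one place only, so no single structural step has yet been measured.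

Compound 3, `COc1cc(NC(C)CCCNC(=O)NNC(=O)Nc2cccc(Cl)c2)c2ncccc2c1`, remains to be measured in this assay. It differs from compound 2 by (3-chlorophenyl)amino in place of 1-methyl-2-phenylethenyl on a carbonyl carbon. The change sits on a carbonyl carbon whose other neighbour is an amide-type nitrogen; the group that leaves carries no hydrogen-bond donor, the group that enters carries one.

Within the data shown here, no measured step covers this change, and compound 2 already sits at the weak end of the two numbers, so the step from compound 2 to compound 3 is expected to be a 1.2-fold higher number from compound 2 to compound 3 (0.06 log units; within the scatter), that is none beyond the scatter, if anything a slight move toward a higher number. Compound 3 is accordingly estimated at 42000 nM, with a range from 15000 nM to 110000 nM.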

Compound 3, half-maximal inhibitory concentration: 58600 nM
For compound 3 the middle estimate is 1.4-fold (0.14 log units) below the measured one, within the range that was stated.
By their numbers in this assay, from the lowest: compound 1; then compounds 2 and 3 (each within the scatter of the next).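

In this assay, within the data shown here, the one step at this carbonyl carbon reads a 1.6-fold higher number from compound 2 to compound 3 (0.21 log units; within the scatter), so (3-chlorophenyl)amino in place of 1-methyl-2-phenylethenyl leaves the read-out within the scatter. Among these compounds, this is the first single-place comparison, and it shows that this exchange, which removes the double bond outside aromatic rings and brings in a chlorine and the hydrogen-bond donor of the entering group, does not move the number beyond the scatter in this pair, although these features change together and a single pair cannot separate them. No measured information is available to explain this outcome.

Still open, from the compounds shown here alone, is whether the chlorine matters on its own, a question that phenylamino at this carbonyl carbon would address, and whether the same flat result holds for groups of a different kind there, such as benzylamino or a simple methylamino. The compounds shown also leave open how the read-out responds to changes elsewhere, for example a longer chain in place of the present one or a carboxylic acid on the phenyl ring.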